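Dropping the Fluoro Group: From Compound 3 to Compound 4

This account rests on a few compounds, and the source may have more. Where it says the series, first, only, none or still open, it means among the compounds named here.

Measured compounds in a functional assay on MOLT-4 cells (Homo sapiens) for antiproliferative activity, read by MTT assay, with a stated time of 48 h; on this read-out higher numbers stand for weaker inhibition and lower numbers for stronger inhibition:
Compound 1 `O=C(CCCCCn1cc(Nc2ncc(Cl)c(Nc3cccc(Cl)c3)n2)cn1)NO` gives 80 nM.
Compound 2 `O=C(CCCCCn1cc(Nc2ncc(Cl)c(Nc3ccccc3Cl)n2)cn1)NO` gives 630 nM.
Compound 3 `O=C(CCCCCCn1cc(Nc2ncc(Cl)c(Nc3ccc(F)cc3)n2)cn1)NO` gives 220 nM.

Among the three numbers, compound 3 holds the second highest number. Its nearest neighbour is compound 1, whose number is lower; compound 2 sits furthest away with a higher number, and both gaps lie beyond the scatter. Among the measured compounds shown here, no single-change step connects compound 3 to either of them. Compound 3 also differs from both in the length of the chain that links the hydroxamic acid to the shared core.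

Compound 4 `O=C(CCCCCCn1cc(Nc2ncc(Cl)c(Nc3ccccc3)n2)cn1)NO` is not yet measured. It differs from compound 3 in one place: hydrogen in place of fluoro on an aromatic carbon.

For the measured compounds named here, the only measured step, a 7.9-fold higher number from compound 1 to compound 2 (0.90 log units; beyond the scatter), moved a chloro group from one position of the phenyl ring to another and does not directly speak to removing a fluoro group. Going by the values given here, with no closer precedent, the estimated step is a 1.4-fold higher number from compound 3 to compound 4 (0.13 log units; within the scatter), which is expected to be a small rise in the number. Compound 4 is therefore estimated at 300 nM, in a range from 120 nM to 800 nM.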

Compound 4, half-maximal inhibitory concentration: 160 nM
Compound 4: the middle estimate sits 1.9-fold (0.27 log units) above what was measured; the measured number falls inside the stated range.
By their numbers in this assay, from the lowest: compounds 1, 4 and 3 (each within the scatter of the next, the first and the last beyond it); then compound 2.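

In this assay, hydrogen in place of fluoro gives a 1.4-fold lower number from compound 3 to compound 4 (0.14 log units; within the scatter), so at this place on the ring, para to a large group, the fluoro group makes no difference that this read-out can resolve. Among the compounds shown here, this is a useful contrast with the only earlier step on the same phenyl ring, a 7.9-fold higher number from compound 1 to compound 2 (0.90 log units; beyond the scatter), which shows that a change on this ring can go beyond the scatter, whereas going from 4-fluorophenyl to phenyl does not. No measurement shown here bears on why the two steps differ in size.

The compounds shown leave open whether a larger or different group at this same place, such as a methoxy group or an amine, would also leave the number within the scatter of compound 4. They also leave open whether the fluoro group would matter as little on the other chain length, since compound 1 and compound 2 carry a different chain and have no partner that differs from them only by losing a ring substituent.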